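The compounds below may be only part of what the source reports. "The series", "measured", "known", "first", "only" and "open" are said of these compounds alone.

Of the compounds shown here, two so far have numbers in a functional assay on MGC-803 cells (Homo sapiens) for inhibition, read by CCK-8 assay, with a stated time of 48 h (a higher number here means a weaker inhibitor, a lower number a stronger inhibitor), to compare. Compound 1 (`COc1cc(N(Cc2ccc(C)cc2)C(=O)CSC(=S)N2CCN(C(=O)OC(C)(C)C)CC2)cc(OC)c1OC`) reads 16700 nM there, and compound 2 (`COc1ccc(CN(C(=O)CSC(=S)N2CCN(C(=O)OC(C)(C)C)CC2)c2cc(OC)c(OC)c(OC)c2)cc1F`) reads 4870 nM there, the lower of the two numbers and so the stronger inhibitor. Compound 3 (`COc1ccc(CN(C(=O)CSC(=S)N2CCN(C(=O)OC(C)(C)C)CC2)c2cc(OC)c(OC)c(OC)c2)cc1C`) has not yet been measured. It departs from compound 2 by one small swap, methyl in place of fluoro on an aromatic carbon, while the methoxy group stays. Within the data shown here, the only measured step that bears on this is a 3.4-fold lower number from compound 1 to compound 2 (0.54 log units; beyond the scatter) and it counts as modest. Among the measured compounds shown here, that step replaced 4-methylphenyl with 3-fluoro-4-methoxyphenyl as a whole, so it does not separate the fluoro from the methoxy, and no measured pair compares fluoro with methyl directly. A smaller step than that one is therefore expected, drifting slightly toward a higher number and probably staying within the usual scatter. The expected change is a 1.3-fold higher number from compound 2 to compound 3 (0.13 log units; within the scatter) overall. For compound 3 the estimate is 6500 nM as the expected value, with a likely range from 2500 nM to 16000 nM around it.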

Compound 3, half-maximal inhibitory concentration: > 20000 nM
Compound 3: a limit, no number; the forecaster's own chance of this, stated with the estimate: 3%; middle value at least 3.0-fold (0.48 log units) away from the limit.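

In this assay, compound 3 gives > 20000 nM, which is a limit of the assay and not a number. Changing only this one atom on the ring, ortho to a methoxy group, gives an at least 4.1-fold higher number from compound 2 to compound 3 (0.61 log units; beyond the scatter), so methyl cannot stand in for fluoro here, and a single-atom swap at this position is enough to move the reading beyond the scatter. The earlier step, a 3.4-fold lower number from compound 1 to compound 2 (0.54 log units; beyond the scatter), changed fluoro and methoxy together, whereas the new step, an at least 1.1-fold higher number from compound 1 to compound 3 (0.07 log units; that floor lies within the scatter), has a floor within the scatter, so compound 3 keeps the methoxy group yet shows no gain over compound 1, and the improvement seen in compound 2 depends on having fluoro rather than methyl at this position.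

Going by these compounds, how much weaker compound 3 truly is stays open, because its reading ends at a limit and gives no exact size for the step: the limit of > 20000 nM in this assay, at which 1 of the 3 values shown sits. Also open is whether fluoro itself is special or whether a chloro group, a hydroxyl group or a plain hydrogen at this position would match compound 2.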